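The compounds below may be only part of what the source reports. "The series", "measured", "known", "first", "only" and "open" are said of these compounds alone.

In a physicochemical assay for solubility, read by chemiluminescence, measured as kinetic solubility (on this read-out lower numbers stand for lower solubility and higher numbers for higher solubility), compound 1 `COc1nn(C)c2nc(C)nc(NS(=O)(=O)c3cccc(Cl)c3Cl)c12` gives >= 557000 nM, which is a limit of the assay. Compound 2 `COc1nn(C)c2nc(N)nc(NS(=O)(=O)c3cccc(Cl)c3Cl)c12` gives >= 649000 nM, also a limit, so it stands at a limit and not at a number. Compound 3 `CCNc1nc(NS(=O)(=O)c2cccc(Cl)c2Cl)c2c(OC)nn(C)c2n1` differs from it by ethyl in place of hydrogen on a nitrogen on an aromatic ring, amino to ethylamino. For the measured compounds named here, the one measured step, a step that the two limits leave unreadable from compound 1 to compound 2, placed amino for methyl on an aromatic carbon and gives no usable size. Only a modest fall is therefore expected in this assay, an uncertain estimate of an at least 1.6-fold lower number from compound 2 to compound 3 (0.21 log units; that floor lies within the scatter). Compound 3 is estimated at 400000 nM, within a range of 130000 nM to 750000 nM.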

Compound 3, solubility: 219000 nM
Compound 3: the middle estimate sits 1.8-fold (0.26 log units) above what was measured; measured number inside the range.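

In this assay, for the compounds shown here, the step from methyl to amino on the aromatic carbon cannot be read, whereas ethyl on the nitrogen gives an at least 2.9-fold lower number from compound 2 to compound 3 (0.47 log units; beyond the scatter), the first readable change at this position, and ethylamino in place of methyl gives an at least 2.5-fold lower number from compound 1 to compound 3 (0.40 log units; beyond the scatter), in the same direction. Both sizes are only floors, and compound 2 stands at a limit: the limit of >= 649000 nM in this assay, at which 1 of the 3 values shown sits. Compound 1 also stands at a limit: the limit of >= 557000 nM in this assay, at which 1 of the 3 values shown sits. The compounds shown leave open whether a longer chain such as propyl on this nitrogen, or a cyclic amine such as morpholine in place of ethylamino, would lower the number further.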